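The source may report more compounds than this note shows. Statements on the series, on what has been measured and on what is new or still open speak of the compounds shown alone.

Measured compounds: compound 3 `COc1ccc(-c2cc(/C=C/C(=O)c3ccc(N)cc3)[nH]n2)cc1OC` gives 26200 nM; compound 1 `COc1cc(-c2cc(/C=C/C(=O)c3ccc(N)cc3)[nH]n2)cc(OC)c1OC` gives 13400 nM; compound 2 `COc1ccc(C(=O)/C=C/c2cc(-c3cc(OC)c(OC)c(OC)c3)n[nH]2)cc1OC` gives 6000 nM, all in a functional assay on A498 cells (Homo sapiens) for inhibition, read by sulforhodamine B assay, with a stated time of 48 h; on this read-out higher numbers stand for lower toxicity in this test and lower numbers for higher toxicity in this test.

Compound 3 and compound 1 differ by one change, (methoxy in place of hydrogen on an aromatic carbon), which made a step of a 2.0-fold lower number from compound 3 to compound 1 (0.29 log units; within the scatter). Compound 2 stands lowest of the three; its difference from compound 3 is not broken down here, while from compound 1 it differs by a 2.2-fold lower number from compound 1 to compound 2 (0.35 log units; beyond the scatter). Compound 4 `COc1cc(C(=O)/C=C/c2cc(-c3cc(OC)c(OC)c(OC)c3)n[nH]2)cc(OC)c1OC` has not been measured. It relates to compound 2 through the same change, (methoxy in place of hydrogen on an aromatic carbon), as compound 1 relates to compound 3. Because that earlier step was a 2.0-fold lower number from compound 3 to compound 1 (0.29 log units; within the scatter), compound 4 is expected to show a step of a 1.7-fold lower number from compound 2 to compound 4 (0.23 log units; within the scatter) in this assay. Compound 4 is thus estimated at 3500 nM, most likely between 1500 nM and 8000 nM.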

Compound 4, concentration lethal to 50% of the cells: 8020 nM
Compound 4: middle estimate off by 2.3-fold (0.36 log units), on the low side; the measured number lies above the stated range.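

In this assay, methoxy in place of hydrogen on an aromatic carbon gave a 1.3-fold higher number from compound 2 to compound 4 (0.13 log units; within the scatter). Set beside the earlier step, the same change on the two cores cannot be told apart: the same change on two cores in this assay, a 2.0-fold lower number (0.29 log units; within the scatter) from compound 3 to compound 1 and a 1.3-fold higher number (0.13 log units; within the scatter) from compound 2 to compound 4, 2.6-fold (0.42 log units) apart, within the scatter of two such steps. This shows that the change stayed small on both cores, but it does not show that it carries a fixed size or direction from one core to the other, as neither step stands clear of the scatter.

The compounds shown leave open whether a different group on that aromatic carbon, such as a hydroxyl or an ethoxy group, would move the number beyond the scatter on either core.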